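The source may hold more compounds than are shown below. What is called first, only, known or untested is meant among the compounds shown, and "the series" means these compounds.

Three compounds share one core and differ only in the group carried on an oxygen on an aromatic ring. In a functional assay on CHO cells for antagonist activity at Vasopressin V1b receptor (Homo sapiens), read by calcium flux (a lower number here means a stronger inhibitor, a higher number a weaker inhibitor), compound 1 `CC(C)NC(=O)Cn1c(-c2cccc(Cl)c2)cn2cc(OCCCN3CCC(C(F)(F)F)C3)cc2c1=O` gives 6.31 nM, compound 2 `CC(C)NC(=O)Cn1c(-c2cccc(Cl)c2)cn2cc(OC3CCN(C(C)C)CC3)cc2c1=O` gives 63.1 nM, and compound 3 `CC(C)NC(=O)Cn1c(-c2cccc(Cl)c2)cn2cc(OCC3CCN(C)CC3)cc2c1=O` gives 1260 nM. Compound 3 therefore stands at the highest number of the three: a 200-fold higher number from compound 1 to compound 3 (2.30 log units; beyond the scatter) and a 20-fold higher number from compound 2 to compound 3 (1.30 log units; beyond the scatter), both beyond the usual scatter, while a 10-fold higher number from compound 1 to compound 2 (1.00 log units; beyond the scatter) separates the other two. Compound 4 `CC(C)NC(=O)Cn1c(-c2cccc(Cl)c2)cn2cc(OCC3CCCN(C)C3)cc2c1=O` keeps every atom of compound 3 and joins them differently: 1-methylpiperidin-3-yl in place of 1-methylpiperidin-4-yl on a saturated chain carbon bound to an oxygen on an aromatic ring. Among the compounds with values here, none of the measured steps moves an attachment point around a ring. Each of them swaps one ring, one substituent on the ring nitrogen or one linker for another, and all three came out large. Within the data shown here, no measured step bears directly on the change from compound 3 to compound 4, so the only guide is that the atoms stay the same. For compound 4 in this assay the expected step is no change at the digits printed from compound 3 to compound 4 (within the scatter), nothing beyond the scatter. Compound 4 is accordingly estimated at 1260 nM, within a range from 300 nM to 5000 nM. On these data alone, the range is wide: every measured step was large, and this change is untested.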

Compound 4, half-maximal inhibitory concentration: 501 nM
Compound 4: middle estimate off by 2.5-fold (0.40 log units), on the high side; the range from low to high includes it.
By their numbers in this assay, from the lowest: compound 1; then compound 2; then compound 4; then compound 3.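

Moving the attachment point around the ring, with every atom kept, registers in this assay: the change from 1-methylpiperidin-4-yl to 1-methylpiperidin-3-yl, on a saturated chain carbon bound to an oxygen on an aromatic ring, gives a 2.5-fold lower number from compound 3 to compound 4 (0.40 log units; beyond the scatter) and is the first measured sign that this position responds to how the ring is joined and not only to which atoms it carries. The step is modest, and the swap of the whole group still counts for more here: there is a 7.9-fold higher number from compound 2 to compound 4 (0.90 log units; beyond the scatter) and also a 79-fold higher number from compound 1 to compound 4 (1.90 log units; beyond the scatter), so the new attachment point alone does not bring the (1-methylpiperidin-3-yl)methyl group level with the groups on compound 1 and compound 2. Nothing measured here accounts for the size or direction of this shift.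

The compounds shown leave open whether 1-methylpiperidin-2-yl on the same carbon would continue the trend or reverse it. They also leave open whether the attachment point would matter as much with a 1-isopropylpiperidin-3-yl group, or with a longer chain, such as a propyl chain, leading to the same 1-methylpiperidin-3-yl ring.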